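Putting an Aromatic Ring Back in Place of Propyl

The source may report more compounds than this note shows. Statements on the series, on what has been measured and on what is new or still open speak of the compounds shown alone.

Two compounds have been measured:
Compound 1, `Cc1ccccc1Cc1cnc(CCc2ccc(-c3ccccc3C(=O)O)cc2)[nH]1`, which in an in vitro functional assay on cells for agonist activity at Bombesin receptor subtype-3 (Mus musculus), read by luminescence and calcium flux (on this read-out higher numbers stand for an effect only at larger amounts of compound and lower numbers for an effect already at smaller amounts), gives 9.3 nM.
Compound 2, `CCCCc1cnc(CCc2ccc(-c3ccccc3C(=O)O)cc2)[nH]1`, which in this assay gives 93 nM.

Compound 2 stands at the higher of the two numbers, so it needs the larger amount to act. Within the data shown here, the only change that separates the two is propyl in place of 2-methylphenyl on a saturated chain carbon bound to an aromatic carbon, and that change brought a 10-fold higher number from compound 1 to compound 2 (1.00 log units; beyond the scatter).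

Compound 3, `O=C(O)c1ccccc1-c1ccc(CCc2ncc(Cc3cccc(F)c3F)[nH]2)cc1`, has not been measured. It differs from compound 2 as follows: 2,3-difluorophenyl in place of propyl on a saturated chain carbon bound to an aromatic carbon. This change runs the earlier step the other way: a six-membered aromatic ring of carbon only again replaces propyl at the same place, this time carrying two fluorines rather than one methyl. Among the measured compounds shown here, only the step from compound 1 to compound 2 bears on this, and it was beyond the scatter. A drop of about the same size is therefore expected, that is a 7.8-fold lower number from compound 2 to compound 3 (0.89 log units; beyond the scatter), landing near compound 1. Compound 3 is estimated at 12 nM, within 4 nM to 50 nM.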

Compound 3, half-maximal effective concentration: 8 nM
For compound 3 the middle estimate is 1.5-fold (0.18 log units) above the measured one; the range from low to high includes it.
By their numbers in this assay, from the lowest: compounds 3 and 1 (each within the scatter of the next); then compound 2.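

In this assay, putting a six-membered aromatic ring of carbon only back at this place, on a saturated chain carbon bound to an aromatic carbon, gives a 12-fold lower number from compound 2 to compound 3 (1.07 log units; beyond the scatter), so the earlier gap to the propyl compound is not tied to the 2-methylphenyl group alone. Exchanging one ring for the other gives a 1.2-fold lower number from compound 1 to compound 3 (0.07 log units; within the scatter), which means that 2-methylphenyl and 2,3-difluorophenyl cannot be told apart here, even though one carries a methyl and the other two fluorines. Nothing measured on these compounds explains why the step from propyl to either ring is so much larger than the step between the rings.

The groups at this place are still only propyl and two substituted phenyl rings, so a cyclohexyl group would be needed to show whether the ring has to be aromatic or whether any six-membered ring of carbon serves as well. Also open, going by these compounds, is how an unsubstituted phenyl group, or a pyridyl ring with nitrogen in the ring, would compare with these two rings.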